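Polymethoxy chain extension from compound 2 to compound 3

The source may report more compounds than this note shows. Statements on the series, on what has been measured and on what is new or still open speak of the compounds shown alone.

Among the measured compounds shown here, in a functional assay on HCT-116 cells (Homo sapiens) for cytotoxicity (a lower number here means a stronger inhibitor, a higher number a weaker inhibitor), compound 1 (`C=CC[C@@H](C[C@@H](C[C@@H](C[C@@H](C[C@@H](C[C@@H](C[C@H](OC)/C(C)=C/CCCCC)OC)OC)OC)OC)OC)OC`) gives 119000 nM and compound 2 (`C=CC[C@@H](C[C@@H](C[C@@H](C[C@@H](C[C@@H](C[C@@H](C[C@@H](C[C@H](OC)/C(C)=C/CCCCC)OC)OC)OC)OC)OC)OC)OC`) gives 106000 nM as the only two numbers measured. The two values lie within the scatter of each other, so compound 2 stands level with compound 1 and no order can be drawn between them.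

Compound 3 (`C=CC[C@@H](C[C@@H](C[C@@H](C[C@@H](C[C@@H](C[C@@H](C[C@@H](C[C@@H](C[C@H](OC)/C(C)=C/CCCCC)OC)OC)OC)OC)OC)OC)OC)OC`) is the next member. The change from compound 2 is 1-methoxybut-3-en-1-yl in place of vinyl on a saturated chain carbon, two bonds along the chain from an oxygen on a saturated carbon and reads in words as 1-methoxybut-3-en-1-yl in place of vinyl on a saturated chain carbon, two bonds along the chain from an oxygen on a saturated carbon.

For the measured compounds named here, one measured step bears on this, the same replacement: a 1.1-fold lower number from compound 1 to compound 2 (0.05 log units; within the scatter) is the whole evidence, and it lies within the scatter. A single step cannot show whether the flat result holds for a further extension. In this assay no change beyond the scatter is therefore expected, and the expected step is a 1.1-fold lower number from compound 2 to compound 3 (0.05 log units; within the scatter) with no direction to rely on. Compound 3 is estimated at 95000 nM with an expected range from 50000 nM to 170000 nM as the working figure.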

Compound 3, half-maximal inhibitory concentration: 86000 nM
Compound 3: the middle estimate sits 1.1-fold (0.04 log units) above what was measured, and the stated range covers the measured number.
By their numbers in this assay, from the lowest: compounds 3, 2 and 1 (each within the scatter of the next).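

In this assay, a second round of the same replacement, 1-methoxybut-3-en-1-yl in place of vinyl on a saturated chain carbon, two bonds along the chain from an oxygen on a saturated carbon, gives a 1.2-fold lower number from compound 2 to compound 3 (0.09 log units; within the scatter) and so extends the flat result of the first round by one further unit. The larger replacement taken in one piece, 1,3-dimethoxyhex-5-en-1-yl in place of vinyl at the same place, gives a 1.4-fold lower number from compound 1 to compound 3 (0.14 log units; within the scatter) and also stays inside the scatter, so the added units do not separate even the two ends of this short series. Nothing available accounts for this flat response.

The compounds shown leave open whether a longer chain of the same kind would still stay within the scatter of these three. They also leave open what a hydroxyl in place of a methoxy, or an amine or a carboxylic acid in place of the allyl, would do to the number, as all three compounds keep the methoxy groups and the allyl.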